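Adding a methyl to the ring nitrogen of compound 3

The source may report more compounds than this note shows. Statements on the series, on what has been measured and on what is new or still open speak of the compounds shown alone.

Measured in a toxicity assay on THP-1 cells (Homo sapiens) for inhibition; a higher number here means that more compound is tolerated, a lower number that less compound is tolerated:
Compound 1 `COc1ccc(-c2cnc(NC(=O)c3ccc(O)cc3)n2C)cc1`: > 100000 nM (a limit)
Compound 2 `Cc1ccc(-c2cnc(NC(=O)c3ccc(F)cc3)n2C)cc1`: 60000 nM
Compound 3 `COc1ccc(-c2cnc(NC(=O)c3ccc(F)cc3)[nH]2)cc1`: > 100000 nM (a limit)

Compound 3 gives > 100000 nM, which is a limit of the assay and not a number. It shares that place with one other compound in the set: the limit of > 100000 nM in this assay, at which 2 of the 3 values shown sit. Compound 4 `COc1ccc(-c2cnc(NC(=O)c3ccc(F)cc3)n2C)cc1` is compound 3 with methyl in place of hydrogen on an aromatic nitrogen. For the measured compounds named here, no measured pair shows this change alone, so the step in this assay can only be judged from the neighbouring compounds. Compound 1 also carries a methyl on that nitrogen, and compound 1 gives > 100000 nM, again a limit. Going by the values given here, compound 2 carries it too, and compound 2 gives 60000 nM, the one true number in the set. On that basis, a small step towards less tolerated compound is expected, or none beyond the scatter, and compound 4 may well return only a limit. The estimated step is an at least 1.2-fold lower number from compound 3 to compound 4 (0.09 log units; that floor lies within the scatter). For compound 4 the estimated value is 80000 nM, with an expected range from 40000 nM to 150000 nM.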

Compound 4, half-maximal cytotoxic concentration: >= 50000 nM
Compound 4: a limit, no number (the forecaster's own chance of this, stated with the estimate: 50%); the middle value does not contradict the limit.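

Compound 4 gives only a limit in this assay, and its steps from compound 1, compound 2 and compound 3 cannot be read. The compounds shown leave open whether methyl in place of hydrogen on an aromatic nitrogen, methoxy in place of methyl or fluoro in place of hydroxy changes how much compound is tolerated.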